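The compounds below may be only part of what the source reports. "The series", "measured", "known", "first", "only" and "open" are said of these compounds alone.

Measured compounds:
- compound 1 `O=C(CSc1nc2ccccc2[nH]1)c1ccc(Br)cc1`: "not active" (no number reported)
- compound 2 `O=C(CSc1nc2ccccc2[nH]1)c1ccc(O)cc1`: "not active" (no number reported)
- compound 3 `Cc1ccc(C(=O)CSc2nc3ccccc3[nH]2)cc1`: 40%

Among the compounds with values here, in a functional assay on HT-29 cells (Homo sapiens) for inhibition, read by flow cytometry, tested at 10 uM (a lower number here means less inhibition, a higher number more inhibition at the concentration tested (going by the name of the read-out)), compound 3 holds the only number; compound 1 and compound 2 come back without a number, each reported as not active, so no step between measured compounds can be given and nothing about the size of any change can be drawn from the measured set alone. The step to compound 4 `O=C(CSc1nc2ccccc2[nH]1)c1ccc(F)cc1` changes the group on the six-membered ring of carbon only: fluoro in place of methyl on an aromatic carbon. Within the data shown here, with no measured step available, the expectation rests on the single number of compound 3 and on the two entries without a number. Compound 4 is expected to fall below compound 3, with the step of a number 20 percentage points lower from compound 3 to compound 4 (beyond the scatter) estimated as a drop beyond the scatter, because compound 3 gives 40% while the other two members of the series return no number at all. Compound 4 is estimated at 20% in this assay, within a range from 0% to 45%, with a fair chance that it too is reported only as not active.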

Compound 4, a percentage reported as inhibition, at one concentration (the size of the read-out at that concentration, not a potency): "not active" (no number reported)
For compound 4 the study gives words and no number, and the estimate cannot be compared.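

No step can be read from compound 3 to compound 4: in this assay compound 4 gives "not active" (no number reported) and carries no number. The compounds shown leave open how large any difference between methyl and fluoro is. No measured evidence bears on this result.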